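Notes: chloro on the benzyl of compound 2

The source may report more compounds than this note shows. Statements on the series, on what has been measured and on what is new or still open speak of the compounds shown alone.

Measured in an ADME assay on KB cells (Homo sapiens) for cytotoxicity; a higher number here means that more compound is needed for the effect, a lower number that less compound is needed
- compound 1 `COC(=O)N1[C@@H]2C=C[C@@](OC)(C(=O)c3c2cc(OC)c(OC)c3OCc2ccccc2)N1C(=O)OC` gives > 300 ug/mL (a limit, not a number)
- compound 2 `COc1cc2c(c(OCc3ccccc3)c1OC)C(=O)[C@]1(OC)C=C[C@H]2N(C(=O)OCC(C)C)N1C(=O)OCC(C)C` gives 94 ug/mL
- compound 3 `COC(=O)N1[C@@H]2C=C[C@@](OC)(C(=O)c3c2cc(OC)c(OC)c3OCc2ccccc2F)N1C(=O)OC` gives 137 ug/mL

Compound 2 at 94 ug/mL and compound 3 at 137 ug/mL lie within the scatter of each other, so the two cannot be ranked. Compound 1 is held only as a limit.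

The next compound, compound 4 `COc1cc2c(c(OCc3ccc(Cl)cc3)c1OC)C(=O)[C@]1(OC)C=C[C@H]2N(C(=O)OCC(C)C)N1C(=O)OCC(C)C`, is compound 2 with one change: chloro in place of hydrogen on an aromatic carbon. This is chloro in place of hydrogen on an aromatic carbon, para to a large group, so benzyloxy becomes (4-chlorobenzyl)oxy.

Among the measured compounds shown here, one measured step bears on this change: an at least 2.1-fold lower number from compound 1 to compound 3 (0.34 log units; beyond the scatter). It is fluoro in place of hydrogen on an aromatic carbon, also on the benzyl ring. Going by these compounds, its full size remains open because of the limit of > 300 ug/mL in this assay, at which 1 of the 3 values shown sits. It also involves a different halogen, and compound 1 differs from compound 2 elsewhere in the structure, so it is only a loose guide. A modest move towards a lower number in this assay is therefore expected, possibly not far beyond the scatter.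

The expected change is a 1.6-fold lower number from compound 2 to compound 4 (0.19 log units; within the scatter). Compound 4 is estimated at 60 ug/mL, with an expected range from 22 ug/mL to 130 ug/mL.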

Compound 4, concentration for half-maximal effect: 42 ug/mL
The estimate for compound 4 lay 1.4-fold (0.15 log units) above the measured number, within the range that was stated.
By their numbers in this assay, from the lowest: compound 4; then compounds 2 and 3 (each within the scatter of the next). At a limit, above all of these: compound 1.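

In this assay, among the compounds shown here, chloro in place of hydrogen on an aromatic carbon, para to a large group, gives a 2.2-fold lower number from compound 2 to compound 4 (0.35 log units; beyond the scatter), the first step on this benzyl ring with a full size that can be read. It also shows that a halogen on this ring can move the number on the core of compound 2, and not only on the core of compound 1. The earlier fluoro step, an at least 2.1-fold lower number from compound 1 to compound 3 (0.34 log units; beyond the scatter), still has no full size, since compound 1 is held only as a limit: the limit of > 300 ug/mL in this assay, at which 1 of the 4 values shown sits.

Both halogen steps shown run towards a lower number and no pair goes against this, but two pairs that differ in the halogen and in the rest of the structure make only a narrow pattern. Open, going by these compounds, are whether chloro at this place gives a step of like size on the core of compound 1, and whether a methoxy group, a nitrile, an amine or a carboxylic acid in place of chloro would move the number the same way.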